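Replacing the para methyl of compound 3 with phenyl

The compounds below may be only part of what the source reports. "The series", "measured", "known", "first", "only" and "open" are said of these compounds alone.

In an ADME assay on a cell-free system (plasma, Homo sapiens) for metabolic stability, with Plasma (Rattus norvegicus) as the target, read by HPLC, at pH 7.4 (on this read-out higher numbers stand for a longer-lived compound and lower numbers for a shorter-lived compound), three esters on a shared core have been measured. Compound 1 `CC(=O)Oc1ccccc1C(=O)O[C@H]1CO[C@H]2[C@@H]1OC[C@H]2OC(=O)C1CC1` gives 0.0322 h, compound 2 `CC(=O)Oc1ccccc1C(=O)O[C@H]1CO[C@H]2[C@@H]1OC[C@H]2OC(=O)c1ccccc1C` gives 0.035 h, and compound 3 `CC(=O)Oc1ccccc1C(=O)O[C@H]1CO[C@H]2[C@@H]1OC[C@H]2OC(=O)c1ccc(C)cc1` gives 0.105 h. Compound 3 stands highest of the three on this read-out: the change a 3.3-fold higher number from compound 1 to compound 3 (0.51 log units; beyond the scatter) and the change a 3.0-fold higher number from compound 2 to compound 3 (0.48 log units; beyond the scatter) both lie beyond the scatter, whereas a 1.1-fold higher number from compound 1 to compound 2 (0.04 log units; within the scatter) stays within it.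

Compound 4 `CC(=O)Oc1ccccc1C(=O)O[C@H]1CO[C@H]2[C@@H]1OC[C@H]2OC(=O)c1ccc(-c2ccccc2)cc1` differs from compound 3 in one place: phenyl in place of methyl on an aromatic carbon of a six-membered aromatic ring of carbon only, para to a large group, so that 4-methylphenyl becomes 4-phenylphenyl.

Among the measured compounds shown here, none of the measured pairs covers a methyl-to-phenyl exchange on this ring. The two steps that bear on it are the modest rises toward compound 3 from the cyclopropyl and 2-methylphenyl esters, which establish the starting point but give no direction for a larger aromatic group in the same position. The expectation is therefore for a number close to that of compound 3, with wide uncertainty.

Compound 4 is expected to give about 0.15 h in this assay, within a range from 0.06 h to 0.4 h. This estimate corresponds to a step of a 1.4-fold higher number from compound 3 to compound 4 (0.15 log units; within the scatter), which is not expected to reach clearly beyond the scatter.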

Compound 4, half-life: > 0.333 h
Compound 4: only a limit was reported; the forecaster's own chance of this, stated with the estimate: 5%; middle value at least 2.2-fold (0.34 log units) away from the limit.
By their numbers in this assay, from the lowest: compounds 1 and 2 (each within the scatter of the next); then compound 3. At a limit, above all of these: compound 4.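

The reading for compound 4 in this assay is a limit of the assay and not a number: the limit of > 0.333 h in this assay, at which 1 of the 4 values shown sits.

Even so, the change has a direction that the earlier compounds could not give: phenyl in place of methyl on an aromatic carbon produces an at least 3.1-fold higher number from compound 3 to compound 4 (0.50 log units; beyond the scatter), so a second aromatic ring at this place, para to a large group, is accompanied by a longer half-life rather than a shorter one. Set against the other two esters, 4-phenylphenyl gives an at least 9.5-fold higher number from compound 2 to compound 4 (0.97 log units; beyond the scatter) and, in place of cyclopropyl, an at least 10-fold higher number from compound 1 to compound 4 (1.01 log units; beyond the scatter), which puts it above every other group on the carbonyl carbon shown here.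

As far as these compounds go, how far the half-life of compound 4 extends past the limit remains unknown, and with it the true size of all three steps. The compounds shown also leave open whether the rise depends on the second ring being aromatic, which a cyclohexyl or pyridine ring at the same place would test, and whether an amine or a carboxylic acid on the outer phenyl would keep it.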